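A few compounds are considered here, and "the series" means these few. Any claim that something is new, unique, unknown or untested is made for them only; others in the source may bear on it.

Of the compounds shown here, three have been measured in a functional assay for antagonist activity at corticotropin-releasing factor receptor 1 (Homo sapiens); on this read-out higher numbers stand for weaker inhibition and lower numbers for stronger inhibition. Compound 1 `CSc1nn(-c2c(Cl)cc(Cl)cc2Cl)c2nc(C)nc(-c3ccccc3C(F)(F)F)c12` gives 33.4 nM in this assay. Compound 2 `COc1cc(Br)c(Nc2nc(C)nc(-c3ccccc3C(F)(F)F)c2N)c(OC)c1` gives 60.3 nM in this assay. Compound 3 `COc1cc(Br)c(-n2c(C)nc3c(-c4ccccc4C(F)(F)F)nc(C)nc32)c(OC)c1` gives 32.3 nM in this assay. On these numbers compound 3 sits at the low end of the three, yet the gap to compound 1 and the gap to compound 2 both fall within the usual scatter of repeated measurements, so no ranking among the three can be read from them.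

The unmeasured compound 4 `COc1cc(Br)c(-n2c(O)nc3c(-c4ccccc4C(F)(F)F)nc(C)nc32)c(OC)c1` differs from compound 3 in one place: hydroxy in place of methyl on an aromatic carbon. Here a hydroxy stands in place of a methyl on an aromatic carbon of the five-membered ring, the position between two ring nitrogen atoms, next to the ring atom that bears the large group.

Among the compounds with values here, no measured pair shows this exchange, so the data give no direct guide to its size. The account treats it as a step toward a higher number in this assay, since compound 3 gives 32.3 nM with a methyl at that position, and the hydroxy brings a donor and an acceptor where none was before. The estimated step from compound 3 to compound 4 is a 4.6-fold higher number from compound 3 to compound 4 (0.67 log units; beyond the scatter), beyond the scatter. Compound 4 is therefore expected to give about 150 nM, within a range from 40 nM to 600 nM.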

Compound 4, inhibition constant: 202 nM
Compound 4: the middle estimate sits 1.3-fold (0.13 log units) below what was measured, and the stated range covers the measured number.
By their numbers in this assay, from the lowest: compounds 3, 1 and 2 (each within the scatter of the next); then compound 4.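

In this assay, within the data shown here, the exchange of methyl for hydroxy on the aromatic carbon between two ring nitrogen atoms gives a clear move toward weaker inhibition (a 6.3-fold higher number from compound 3 to compound 4 (0.80 log units; beyond the scatter)), the only step in this set between compounds that differ in one place. The earlier compounds shown here differ from one another in more than one place and lie within the scatter of each other, so they said nothing about this position, whereas this pair shows that the read-out responds to a single heavy atom exchanged here, with a hydrogen-bond donor and a hydrogen-bond acceptor entering. No measurement presented here explains the direction or size of this step.

A single exchange leaves open whether the shift belongs to hydroxy in particular or would also follow from other groups on this carbon, such as an amine, an ethyl chain or a fluorine atom. As far as these compounds go, it is also open whether the same exchange would give a step of similar size on the core of compound 1 or in compounds that carry other groups elsewhere.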